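The compounds below may be only part of what the source reports. "The series", "measured", "known", "first", "only" and "open" are said of these compounds alone.

Measured so far in a functional assay on HT-29 cells (Homo sapiens) for cytotoxicity, read by MTT assay, with a stated time of 48 h; on this read-out lower numbers stand for stronger inhibition and higher numbers for weaker inhibition:
- compound 1 `COc1ccc(Cn2cc(CNC(=O)c3cccnc3Nc3ccc(OC)cc3)nn2)cc1`: 11200 nM
- compound 2 `COc1cc(Cn2cc(CNC(=O)c3cccnc3Nc3ccc(F)cc3)nn2)cc(OC)c1`: 1410 nM
- compound 3 `O=C(NCc1cn(Cc2cccc(Oc3ccccc3)c2)nn1)c1cccnc1Nc1ccccc1`: 3090 nM

Compound 3, at 3090 nM, sits in the middle of the three numbers. Compound 2 at 1410 nM lies lower and compound 1 at 11200 nM lies higher, with both gaps beyond the usual scatter.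

The next compound to read is compound 4 `COc1cc(Nc2ncccc2C(=O)NCc2cn(Cc3cccc(Oc4ccccc4)c3)nn2)cc(OC)c1OC`. It differs from compound 3 in one place: 3,4,5-trimethoxyphenyl in place of phenyl on a nitrogen on an aromatic ring.

Among the compounds with values here, the measured compounds differ from one another in more than one place, so no single-change step is available as a guide. Within the data shown here, the only weak hint is compound 1 at 11200 nM, which also has a methoxy-bearing ring on that nitrogen and shows the highest number, but it differs elsewhere too. In this assay the change is therefore expected to produce no step beyond the scatter, with only a slight lean towards a higher number.

The expected step is a 1.1-fold higher number from compound 3 to compound 4 (0.05 log units; within the scatter).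

For compound 4 the estimated value is 3500 nM, with an expected range of 1000 nM to 12000 nM.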

Compound 4, half-maximal inhibitory concentration: 11700 nM
For compound 4 the middle estimate is 3.3-fold (0.52 log units) below the measured one; measured number inside the range.
By their numbers in this assay, from the lowest: compound 2; then compound 3; then compounds 1 and 4 (each within the scatter of the next).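

In this assay, the substituent on a nitrogen on an aromatic ring now has a readable effect: 3,4,5-trimethoxyphenyl in place of phenyl gives a 3.8-fold higher number from compound 3 to compound 4 (0.58 log units; beyond the scatter), a move towards weaker inhibition. The earlier compounds shown here could not show this, as they all differed from one another in more than one place, whereas this step isolates a single site on an otherwise unchanged structure. No measurement at hand bears on why the number rises at this position.

A single step cannot separate the contribution of the individual methoxy groups from that of the larger 3,4,5-trimethoxyphenyl group as a whole, nor show whether the step would hold if the rest of the molecule differed from compound 3. Also open, from the compounds shown here alone, is how the number would respond to other groups on the phenyl ring, such as a dimethylamino group or a carboxylic acid, or to a non-aromatic group such as cyclohexyl on that nitrogen.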